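The source may hold more compounds than are shown below. What is called first, only, known or untested is meant among the compounds shown, and "the series" means these compounds.

Working notes on the series. In an ADME assay on BHK cells (Mesocricetus auratus) for cytotoxicity, read by MTT assay, with a stated time of 96 h (a lower number here means that less compound is tolerated, a higher number that more compound is tolerated), compound 1 (`O=[N+]([O-])c1ccccc1-c1nc2ccccc2[nH]1`) gives > 100000 nM, a limit of the assay and not a number. Compound 2 (`Oc1ccc(-c2nc3cc(C(F)(F)F)ccc3[nH]2)cc1`) gives > 100000 nM, also a limit. Compound 3 (`COc1cc(OC)cc(-c2nc3cc(C(F)(F)F)ccc3[nH]2)c1`) gives > 100000 nM, again a limit. Compound 3 therefore has no exact value and stands with the other two at the limit of > 100000 nM in this assay, at which 3 of the 3 values shown sit.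

Compound 4 (`COc1cc(-c2nc3cc(C(F)(F)F)ccc3[nH]2)cc(OC)c1OC`) follows from compound 3 with methoxy in place of hydrogen on an aromatic carbon, ortho to two methoxy groups and para to a large group: methoxy in place of hydrogen on an aromatic carbon.

Within the data shown here, the series holds no measured step that could size this change in this assay, so the expectation is weakly founded. The most likely outcome is no change beyond the scatter, with a modest chance of a lower reading, meaning less compound tolerated. The estimated step of an at least 1.4-fold lower number from compound 3 to compound 4 (0.15 log units; that floor lies within the scatter) is expected to be small. For compound 4 the expected value is 70000 nM, with an estimated range of 20000 nM to 100000 nM.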

Compound 4, half-maximal cytotoxic concentration: 31000 nM
Estimate against measurement, compound 4: 2.3-fold (0.35 log units) above, and the stated range covers the measured number.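

In this assay, methoxy in place of hydrogen on the aromatic carbon ortho to two methoxy groups and para to a large group gives an at least 3.2-fold lower number from compound 3 to compound 4 (0.50 log units; beyond the scatter). Compound 4 is thus the only compound shown with a reading that is a number and not a limit, and this position is the first place in the series where a single change registers in this assay. The step gives a floor and not a full size, because its starting point is a limit of the assay: the limit of > 100000 nM in this assay, at which 3 of the 4 values shown sit.

As far as these compounds go, whether a hydroxyl, an amine or an ethoxy chain at this same position would also lower the number remains open. Also open, from the compounds shown here alone, is whether methoxy here would have the same effect without the two methoxy groups already on the ring.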